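Shortening the alkyl chain on the ether oxygen of compound 3

A few compounds are considered here, and "the series" means these few. Any claim that something is new, unique, unknown or untested is made for them only; others in the source may bear on it.

Measured compounds and their binding numbers:
Compound 1 `COc1ccc(-c2cc(NNC(=O)Nc3cc(Cl)nc(OC(C)C)c3)nc3c2cnn3C)cc1` gives 2320 nM in an assay on isolated protein for binding affinity to sphingosine 1-phosphate receptor 2 (Homo sapiens), read by surface plasmon resonance; a lower number here means tighter binding, a higher number weaker binding.
Compound 2 `COc1ccc(-c2cc(NNC(=O)Nc3cc(Cl)nc(OC)c3)nc3c2cnn3C)cc1` gives 1980 nM in this assay.
Compound 3 `CCCCOc1cc(NC(=O)NNc2cc(-c3ccc(OC)cc3)c3cnn(C)c3n2)cc(Cl)n1` gives 4150 nM in this assay.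

All three share one core and differ only in the alkyl group on the oxygen attached to the chlorine-bearing aromatic ring. Compound 3 carries the butyl group. It is separated beyond the scatter only from compound 2, as shown by a 2.1-fold higher number from compound 2 to compound 3 (0.32 log units; beyond the scatter); its gap to compound 1, a 1.8-fold higher number from compound 1 to compound 3 (0.25 log units; within the scatter), lies within the scatter, as does the gap between the other two, a 1.2-fold lower number from compound 1 to compound 2 (0.07 log units; within the scatter).

Compound 4 `CCCOc1cc(NC(=O)NNc2cc(-c3ccc(OC)cc3)c3cnn(C)c3n2)cc(Cl)n1` is the next member of this series. Its difference from compound 3 is hydrogen in place of methyl on a saturated chain carbon, three bonds along the chain from an oxygen on an aromatic ring, so the butyl becomes a propyl, a chain one carbon shorter. The step from methyl to butyl across compounds 2 and 3 raised the number only modestly, and the step from isopropyl to butyl changed nothing beyond the scatter. Cutting one carbon back is therefore expected to move the number little, if at all, perhaps slightly downward, by a 1.3-fold lower number from compound 3 to compound 4 (0.11 log units; within the scatter). Compound 4 is estimated at 3200 nM, with a range from 1800 nM to 5600 nM.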

Compound 4, dissociation constant: 3140 nM
Compound 4: the middle estimate sits 1.0-fold (0.01 log units) above what was measured, within the range that was stated.
By their numbers in this assay, from the lowest: compounds 2, 1, 4 and 3 (each within the scatter of the next, the first and the last beyond it).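

In this assay, the propyl chain fills the gap between methyl and butyl, and cutting butyl back to propyl gives a 1.3-fold lower number from compound 3 to compound 4 (0.12 log units; within the scatter), so removing this one carbon at the end of the chain does not separate the two compounds. The propyl compound also stays within the scatter of the methyl compound, with a 1.6-fold higher number from compound 2 to compound 4 (0.20 log units; within the scatter), and of the branched isopropyl compound, with a 1.4-fold higher number from compound 1 to compound 4 (0.13 log units; within the scatter). The only gap beyond the scatter is therefore still the one between the methyl and butyl ends of the series, a 2.1-fold higher number from compound 2 to compound 3 (0.32 log units; beyond the scatter), and the propyl compound now sits inside that gap without a clear break on either side. No measurement at hand explains why the number moves so little across these chains.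

On these data alone, all four compounds carry a plain saturated alkyl group on this oxygen, so it remains open whether a much longer chain such as octyl, or a ring such as cyclopropyl or phenyl, would shift the number well beyond the scatter. A chain ending in an amine or a carboxylic acid, or a bare hydroxyl with no alkyl group at all, is also left open.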